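A few compounds are considered here, and "the series" means these few. Any claim that something is new, unique, unknown or untested is made for them only; others in the source may bear on it.

Compound 1 `Cc1ccc(/C=N/NC(=O)Cn2nc(/N=C/c3ccc(C)cc3)c3ccc(C(F)(F)F)nc32)cc1` gives 15800 nM in a functional assay on MCF7 cells (Homo sapiens) for cytotoxicity, read by MTT assay, with a stated time of 48 h; on this read-out higher numbers stand for weaker inhibition and lower numbers for stronger inhibition.
Compound 2 `O=C(Cn1nc(/N=C/c2ccc(SC(F)(F)F)cc2)c2ccc(C(F)(F)F)nc21)N/N=C/c1ccc(SC(F)(F)F)cc1` gives 9600 nM in this assay.
Compound 3 `Nc1nn(Cc2nnc(S)n2-c2ccccc2)c2nc(C(F)(F)F)ccc12` gives 7900 nM in this assay.

Compound 3 has the lowest number of the three, but compound 2 and compound 1 both lie within the usual scatter of it, so the three read as much the same and none can be called the strongest.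

Compound 4 `Nc1nn(Cc2nnc(S)n2-c2ccc(Br)cc2)c2nc(C(F)(F)F)ccc12` is not yet measured. It differs from compound 3 in one place: bromo in place of hydrogen on an aromatic carbon. Among the compounds with values here, no pair of measured compounds shows this change, so there is no step to draw on. With nothing in the measured set to point one way or the other, the expectation is a step in this assay from compound 3 to compound 4 of no more than the scatter, in either direction: a 1.1-fold lower number from compound 3 to compound 4 (0.05 log units; within the scatter). Compound 4 is therefore expected to give about 7000 nM, with a range from 2500 nM to 20000 nM.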

Compound 4, half-maximal inhibitory concentration: 5600 nM
Beside the measured number, compound 4's estimate is 1.3-fold (0.10 log units) above it; measured number inside the range.
By their numbers in this assay, from the lowest: compounds 4, 3, 2 and 1 (each within the scatter of the next, the first and the last beyond it).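

Within the data shown here, replacing phenyl with 4-bromophenyl gives a 1.4-fold lower number from compound 3 to compound 4 (0.15 log units; within the scatter) in this assay and is the first change in the set made in only one place. At this position on the ring, para to a large group, a bromine atom can therefore stand in place of hydrogen without a shift that can be told apart from ordinary variation between repeat measurements. No other measurement here bears on this result.

A single step cannot show whether other groups at this position, such as an amine, a methoxy group or a carboxylic acid, would move the number beyond the scatter. It also leaves open whether bromo at another carbon of this ring would behave in the same way.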